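The compounds below may be only part of what the source reports. "The series", "measured", "known", "first", "only" and "open" are said of these compounds alone.

Of the compounds shown here, three have been measured so far in an assay on CHO cells for displacement of a labelled ligand from adenosine receptor A3 (Homo sapiens), tested at 10 uM (a higher number here means more inhibition at the concentration tested (going by the name of the read-out), a lower number less inhibition), and none of them displaces the labelled ligand to any visible extent. Compound 1 `O=C1CCCc2[nH]c(=O)c(C(=O)c3ccccc3)cc21` gives 0%. Compound 2 `O=C1CC(c2ccccc2)Cc2[nH]c(=O)c(C(=O)c3ccccc3)cc21` gives 0%, and compound 3 `O=C(c1ccccc1)c1cc(S(=O)(=O)c2ccccc2)c(=O)[nH]c1-c1ccccc1` gives 0%. Among the compounds with values here, the one single-point step among them, no change at the digits printed from compound 1 to compound 2 (within the scatter), shows that adding a phenyl on a saturated ring carbon left the read-out where it was. Compound 2 thus stands level with compound 1 and compound 3 at the digits shown.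

Compound 4 `CC(C)(C)C(=O)c1cc2c([nH]c1=O)CC(c1ccccc1)CC2=O` is the next compound. It differs from compound 2 by tert-butyl in place of phenyl on a carbonyl carbon. Within the data shown here, no measured step touches this carbonyl substituent, so the only guidance is that every compound so far, whatever its decoration, sits at zero. The step from compound 2 to compound 4 is therefore expected to be no change at the digits printed from compound 2 to compound 4 (within the scatter), no change beyond the scatter. For compound 4 the estimate is 0%, with a range from -8% to 12%.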

Compound 4, a percentage reported as inhibition, at one concentration (the size of the read-out at that concentration, not a potency): 21%
Beside the measured number, compound 4's estimate is 21 percentage points below it; the whole stated range lies below it.
By their numbers in this assay, from the lowest: compounds 1, 2 and 3 (each within the scatter of the next); then compound 4.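

Replacing benzoyl with (tert-butyl)carbonyl gives a number 21 percentage points higher from compound 2 to compound 4 (beyond the scatter) in this assay and is the first change shown to lift this read-out above zero. The earlier step, a phenyl on a saturated ring carbon, left the number unmoved, so the group on the carbonyl carbon is the one place shown so far where a change registers. Nothing available explains the rise.

As far as these compounds go, whether it reflects the loss of the aromatic ring or something particular to tert-butyl stays open, and a cyclohexyl group or a straight butyl chain on the same carbonyl carbon would help tell these apart. Also open, from the compounds shown here alone, is whether (tert-butyl)carbonyl has the same effect on the core of compound 1, which lacks the phenyl on the saturated ring carbon.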